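Selenium alkylation on two cores: notes toward compound 4

The source may hold more compounds than are shown below. What is called first, only, known or untested is meant among the compounds shown, and "the series" means these compounds.

Three compounds have been run in a functional assay on CCRF-CEM cells (Homo sapiens) for cytotoxicity, read by MTT assay, with a stated time of 72 h; on this read-out higher numbers stand for weaker inhibition of growth and lower numbers for stronger inhibition of growth. Compound 1 `CCCCC[Se]c1nc(NCc2ccc(SC)cc2)c2ccccc2n1` gives 35000 nM. Compound 2 `CSc1ccc(CNc2nc([SeH])nc3ccccc23)cc1` gives 71900 nM. Compound 3 `Nc1nc([SeH])nc2ncccc12` gives 30900 nM; against compound 1 the two values sit within the scatter, while against compound 2 compound 3 stands beyond it.

Compound 2 and compound 1 differ in one place: pentyl in place of hydrogen on a selenium. This single change gave a 2.1-fold lower number from compound 2 to compound 1 (0.31 log units; beyond the scatter), a modest but real drop in the number from compound 2 to compound 1.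

Compound 4 `CCCCC[Se]c1nc(N)c2cccnc2n1` has not been measured. Compound 4 stands to compound 3 as compound 1 stands to compound 2: pentyl in place of hydrogen on a selenium. The place is the same word for word in both pairs, so the change is the same, not merely the same kind. The difference between the core of compound 3 and the core of compound 2 is not broken down here, so the precedent comes from a different core and rests on one pair only.

In this assay the expected step is a 1.9-fold lower number from compound 3 to compound 4 (0.29 log units; within the scatter), taken to match the earlier step because of a 2.1-fold lower number from compound 2 to compound 1 (0.31 log units; beyond the scatter) on the other core, with the range widened for the change of core. Compound 4 is therefore estimated at 16000 nM, with a likely span from 7000 nM to 40000 nM.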

Compound 4, concentration for 50% growth inhibition: 12900 nM
Beside the measured number, compound 4's estimate is 1.2-fold (0.09 log units) above it, and the stated range covers the measured number.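

In this assay, pentyl in place of hydrogen on a selenium gave a 2.4-fold lower number from compound 3 to compound 4 (0.38 log units; beyond the scatter), and this step agrees with the one seen on the other core: the same change on two cores in this assay, a 2.1-fold lower number (0.31 log units; beyond the scatter) from compound 2 to compound 1 and a 2.4-fold lower number (0.38 log units; beyond the scatter) from compound 3 to compound 4, 1.2-fold (0.07 log units) apart, within the scatter of two such steps

In this series, then, the change carries from the core of compound 2 to the core of compound 3 in the same direction, towards stronger inhibition of growth, and with a size that cannot be told apart between the two cores. This rests on two pairs and two cores only, so it is no rule for other cores, it gives no reason for the step, and it does not rank the two cores against each other, since they differ in more than one place.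

The compounds shown have only hydrogen or pentyl on the selenium, so they leave open how the step changes with a shorter chain such as methyl, a longer chain such as octyl, or a chain ending in an amine or a carboxylic acid. They also leave open whether a sulfur in place of the selenium would give a step of similar size, and whether the step would hold on a third core.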